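The compounds below may be only part of what the source reports. "The series", "measured", "known", "first", "only" and "open" are said of these compounds alone.

Of the compounds shown here, two of a shared core have been measured. Compound 1 `O=C(O)c1ccccc1-c1ccc(CCc2ncc(Cc3ccc(F)cc3)[nH]2)cc1` carries a 4-fluorophenyl group, and in an in vitro functional assay on cells for agonist activity at Bombesin receptor subtype-3 (Homo sapiens), read by luminescence and calcium flux (a lower number here means that less compound is needed, a higher number that more compound is needed for the effect), compound 1 gives 1600 nM. Compound 2 `O=C(O)c1ccccc1-c1ccc(CCc2ncc(Cc3cccc(F)c3F)[nH]2)cc1` differs only in that a 2,3-difluorophenyl group takes the place of the 4-fluorophenyl group on a saturated chain carbon bound to an aromatic carbon, and in this assay compound 2 gives 87 nM. That single change gives an 18-fold lower number from compound 1 to compound 2 (1.26 log units; beyond the scatter), so compound 2 stands with the lowest number of the two.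

Compound 3 `O=C(O)c1ccccc1-c1ccc(CCc2ncc(CC3CCCCCC3)[nH]2)cc1` is not yet measured. It differs from compound 2 by cycloheptyl in place of 2,3-difluorophenyl on a saturated chain carbon bound to an aromatic carbon. Among the measured compounds shown here, only one measured step exists, and it concerns the pattern of fluorine on an aromatic ring, whereas this change exchanges the aromatic ring itself for a saturated seven-membered ring. That step, an 18-fold lower number from compound 1 to compound 2 (1.26 log units; beyond the scatter), shows that this position is sensitive to what sits there, but it gives no direction for the present change. The number for compound 3 in this assay is therefore expected with wide uncertainty, around 400 nM, plausibly anywhere from 60 nM to 3000 nM, which would mean a step of a 4.6-fold higher number from compound 2 to compound 3 (0.66 log units; beyond the scatter).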

Compound 3, half-maximal effective concentration: 88 nM
The estimate for compound 3 lay 4.5-fold (0.66 log units) above the measured number; the measured number falls inside the stated range.
By their numbers in this assay, from the lowest: compounds 2 and 3 (each within the scatter of the next); then compound 1.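

In this assay, replacing 2,3-difluorophenyl with cycloheptyl gives a 1.0-fold higher number from compound 2 to compound 3 (0.00 log units; within the scatter), so among these compounds an aromatic ring and fluorine are not required at this position: a non-aromatic ring of carbon only serves as well. The same group, set against the 4-fluorophenyl group, gives an 18-fold lower number from compound 1 to compound 3 (1.26 log units; beyond the scatter), which leaves compound 1 as the one that stands apart among the three, while two quite different rings give numbers that cannot be told apart. Nothing available here explains why these two rings match or why the 4-fluorophenyl group differs from both.

As far as these compounds go, what remains open is how much ring size matters, since a cyclohexyl or cyclopentyl group in this place, or an open chain such as n-hexyl, could show whether the seven-membered ring has any special value. From the compounds shown here alone, it is also open whether this position would accept a group of a different kind, such as an amine or a hydroxyl on the cycloheptyl ring, and whether any replacement could bring the number clearly lower than those of compound 2 and compound 3.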